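The source may hold more compounds than are shown below. What is called first, only, known or untested is meant among the compounds shown, and "the series" means these compounds.

Compound 1 `c1ccc(C2CNCCN2c2ccc3[nH]ncc3c2)cc1` is tested in an assay on HEK293 cells for displacement of a labelled ligand from sodium-dependent dopamine transporter (Homo sapiens), read by scintillation proximity assay (on this read-out higher numbers stand for weaker inhibition and lower numbers for stronger inhibition), where compound 1 gives 200 nM. Among the three compounds measured so far, compound 1 stands at the highest number: compound 2 `CCCCC1CNCCN1c1ccc2[nH]ncc2c1` gives 31.6 nM in this assay, and compound 3 `CC(C)CC1CNCCN1c1ccc2[nH]ncc2c1` gives 15.9 nM. Both steps away from compound 1 lower the number, a 6.3-fold lower number from compound 1 to compound 2 (0.80 log units; beyond the scatter) and a 13-fold lower number from compound 1 to compound 3 (1.10 log units; beyond the scatter), while between the two chains the difference is a 2.0-fold lower number from compound 2 to compound 3 (0.30 log units; within the scatter). Compound 4 `COCCC1CNCCN1c1ccc2[nH]ncc2c1` is not yet measured. It differs from compound 1 as follows: 2-methoxyethyl in place of phenyl on a saturated ring carbon. For the measured compounds named here, the steps from compound 1 to compound 2 and to compound 3 bear on this change, since each replaces the phenyl with a chain on the same saturated ring carbon; the entering 2-methoxyethyl is likewise a chain, though it brings a hydrogen-bond acceptor that butyl and isobutyl lack, a feature no measured step covers. A lower number is therefore expected, with the expected step being a 3.2-fold lower number from compound 1 to compound 4 (0.50 log units; beyond the scatter), smaller than a 13-fold lower number from compound 1 to compound 3 (1.10 log units; beyond the scatter). Compound 4 is estimated at 63 nM in this assay, within a range from 20 nM to 200 nM.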

Compound 4, inhibition constant: 158 nM
For compound 4 the middle estimate is 2.5-fold (0.40 log units) below the measured one; the range from low to high includes it.
By their numbers in this assay, from the lowest: compounds 3 and 2 (each within the scatter of the next); then compounds 4 and 1 (each within the scatter of the next).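

In this assay, exchanging the phenyl for a chain on this saturated ring carbon does not by itself bring the lower numbers seen with butyl and isobutyl, as 2-methoxyethyl leaves the number within the scatter (a 1.3-fold lower number from compound 1 to compound 4 (0.10 log units; within the scatter)). The oxygen in the chain therefore marks the difference among the chains: methoxy in place of ethyl, two bonds along the chain from the saturated ring carbon, gives a step beyond the scatter (a 5.0-fold higher number from compound 2 to compound 4 (0.70 log units; beyond the scatter)), and methoxymethyl in place of isopropyl gives another (a 9.9-fold higher number from compound 3 to compound 4 (1.00 log units; beyond the scatter)). Nothing available here accounts for this difference between the chains.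

The compounds shown leave open whether an oxygen further along a longer chain, as in 3-methoxypropyl, would give the same result. They also leave open how a 2-hydroxyethyl or 2-aminoethyl chain would compare at this position.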